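Fluoro in place of chloro: compound 3 awaits its number

The source may report more compounds than this note shows. Statements on the series, on what has been measured and on what is new or still open speak of the compounds shown alone.

In an ADME assay on HepG2 cells (Homo sapiens) for cytotoxicity, with a stated time of 72 h (a lower number here means that less compound is needed, a higher number that more compound is needed for the effect), compound 2 (`COc1ccc(NC(=O)Nc2cc(C)nc3ccccc23)cc1Cl`) stands at > 25000 nM as a limit of the assay, not as a number. Compound 1 (`Cc1cc(NC(=O)Nc2ccc(F)c(F)c2)c2ccccc2n1`) gives 21000 nM in this assay as a measured number. Compound 3 (`COc1ccc(NC(=O)Nc2cc(C)nc3ccccc23)cc1F`) carries fluoro in place of chloro on an aromatic carbon, ortho to a methoxy group (fluoro in place of chloro on an aromatic carbon). Among the compounds with values here, no measured pair shows such an exchange, and the expected a number no higher from compound 2 to compound 3 (the limit leaves the size open) in this assay is no change beyond the scatter. For compound 3 the estimated value is 25000 nM with an expected range from 13000 nM to 40000 nM in this assay.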

Compound 3, half-maximal effective concentration: > 25000 nM
Compound 3: only a limit was reported (the forecaster's own chance of this, stated with the estimate: 55%); the middle value sits exactly at the limit.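

In this assay, compound 3 also gives only a limit, so on this aromatic carbon, ortho to a methoxy group, neither fluoro nor chloro yields a measured number: the limit of > 25000 nM in this assay, at which 2 of the 3 values shown sit. The step between the two limits cannot be read. Within the data shown here, the one readable step is an at least 1.1-fold higher number from compound 1 to compound 3 (0.07 log units; that floor lies within the scatter), which sets no order between these compounds.

The compounds shown leave open whether any group at this position gives a measured number under the limit. On these data alone, an amine or a carboxylic acid here remains untested among them.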